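The source may report more compounds than this note shows. Statements on the series, on what has been measured and on what is new or still open speak of the compounds shown alone.

Measured so far in a functional assay on MDA-MB-435 cells (Homo sapiens) for cytotoxicity, read by MTT assay, with a stated time of 72 h; on this read-out higher numbers stand for weaker inhibition and lower numbers for stronger inhibition:
- compound 1 `N[C@H]1CC[C@H](Nc2c(C(=O)NCc3ccc(F)cc3)nc(Br)c3cccnc23)CC1`: 6000 nM
- compound 2 `COc1ccc(CNC(=O)c2nc(Br)c3cccnc3c2N[C@H]2CC[C@H](N)CC2)cc1`: 5000 nM
- compound 3 `N[C@H]1CC[C@H](Nc2c(C(=O)NCc3ccc(Cl)cc3)nc(Br)c3cccnc23)CC1`: 1000 nM

Compound 3 has the lowest number of the three. Compound 4 `N[C@H]1CC[C@H](Nc2c(C(=O)NCc3ccccc3)nc(Br)c3cccnc23)CC1` has hydrogen in place of chloro on an aromatic carbon, para to a large group, so 4-chlorobenzyl becomes benzyl (hydrogen in place of chloro on an aromatic carbon). The same ring position was varied in the measured compounds. Chloro stood apart in a 6.0-fold lower number from compound 1 to compound 3 (0.78 log units; beyond the scatter) and in a 5.0-fold lower number from compound 2 to compound 3 (0.70 log units; beyond the scatter), while a 1.2-fold lower number from compound 1 to compound 2 (0.08 log units; within the scatter) showed no separation between the other two groups. Among the compounds with values here, no measured compound carries hydrogen there. A move to a higher number in this assay is therefore expected, of similar or slightly smaller size than those two steps. The expected step is a 4.0-fold higher number from compound 3 to compound 4 (0.60 log units; beyond the scatter). For compound 4 the estimate is 4000 nM, with an expected range from 1500 nM to 10000 nM.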

Compound 4, half-maximal inhibitory concentration: 7000 nM
The estimate for compound 4 lay 1.8-fold (0.24 log units) below the measured number; low and high end bracket the measured number.
By their numbers in this assay, from the lowest: compound 3; then compounds 2, 1 and 4 (each within the scatter of the next).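

Hydrogen gives this position an unsubstituted reference that the earlier compounds lacked: the change from chloro shows a 7.0-fold higher number from compound 3 to compound 4 (0.85 log units; beyond the scatter), while the steps from the other two groups read a 1.4-fold higher number from compound 2 to compound 4 (0.15 log units; within the scatter) and a 1.2-fold higher number from compound 1 to compound 4 (0.07 log units; within the scatter). Fluoro and methoxy therefore do not separate from hydrogen, and among these four compounds only compound 3, with its 4-chlorobenzyl group, stands apart. Nothing available explains this separation.

On these data alone, whether bromo or trifluoromethyl at the same position would separate from hydrogen as chloro does remains open. Also open, as far as these compounds go, is whether the chloro step would persist with an amine in place of the bromo on the shared core.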